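Swapping the Amide Aryl Group on a Carboxylic Acid Core

A few compounds are considered here, and "the series" means these few. Any claim that something is new, unique, unknown or untested is made for them only; others in the source may bear on it.

Four compounds share one core that carries an anilide arm and a piperazine-bearing aniline. Compound 1 `CCOC(=O)c1sc(-c2cccc(NC(=O)c3ccccc3F)c2)nc1Nc1ccc(N2CCN(C)CC2)cc1` is an ethyl ester; in a functional assay on Raji cells (Homo sapiens) for antiproliferative activity, read by CCK-8 assay, with a stated time of 72 h, tested at 40 uM (a higher number here means more inhibition at the concentration tested (going by the name of the read-out), a lower number less inhibition), compound 1 gives 89.8%. Compound 2 `CCOC(=O)c1sc(-c2cccc(NC(=O)c3ccc(Cl)cc3)c2)nc1Nc1ccc(N2CCN(C)CC2)cc1` differs from compound 1 by 4-chlorophenyl in place of 2-fluorophenyl on a carbonyl carbon, and in this assay compound 2 gives 24.3%; the step of a number 65.5 percentage points lower from compound 1 to compound 2 (beyond the scatter) is large. Compound 3 `CN1CCN(c2ccc(Nc3nc(-c4cccc(NC(=O)c5ccccc5F)c4)sc3C(=O)O)cc2)CC1` differs from compound 1 by hydrogen in place of ethyl on an oxygen next to a carbonyl group. In this assay compound 3 gives 86.9%, and the step of a number 2.9 percentage points lower from compound 1 to compound 3 (within the scatter) shows that the acid and the ester behave alike here. Compound 4 `CN1CCN(c2ccc(Nc3nc(-c4cccc(NC(=O)c5ccc(Cl)cc5)c4)sc3C(=O)O)cc2)CC1` has not been measured. It differs from compound 3 by 4-chlorophenyl in place of 2-fluorophenyl on a carbonyl carbon, the same change as from compound 1 to compound 2, made at the same place, on a carbonyl carbon whose other neighbour is an amide-type nitrogen. The expectation rests on the earlier step of a number 65.5 percentage points lower from compound 1 to compound 2 (beyond the scatter) and on compound 3 giving 86.9%, close to compound 1. A fall of similar size is expected: a number 64.9 percentage points lower from compound 3 to compound 4 (beyond the scatter). Compound 4 is therefore estimated to give 22%, with a likely range from 5% to 45%.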

Compound 4, a percentage reported as inhibition, at one concentration (the size of the read-out at that concentration, not a potency): 90.9%
The estimate for compound 4 lay 68.9 percentage points below the measured number; measured number outside the range, above it.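

In this assay, putting 4-chlorophenyl in place of 2-fluorophenyl on the acid gives a number 4 percentage points higher from compound 3 to compound 4 (within the scatter), so the large fall seen on the ethyl ester does not carry over to the acid: the same change on two cores in this assay, a number 65.5 percentage points lower (beyond the scatter) from compound 1 to compound 2 and a number 4 percentage points higher (within the scatter) from compound 3 to compound 4, 69.5 percentage points apart, beyond the scatter of two such steps. Likewise, hydrogen in place of ethyl, which changed little with 2-fluorophenyl, gives a number 66.6 percentage points higher from compound 2 to compound 4 (beyond the scatter) with 4-chlorophenyl on the amide: the same change on two cores in this assay, a number 2.9 percentage points lower (within the scatter) from compound 1 to compound 3 and a number 66.6 percentage points higher (beyond the scatter) from compound 2 to compound 4, 69.5 percentage points apart, beyond the scatter of two such steps. Among these compounds, in these four compounds, then, the effect of each change depends on the other, so the two cannot be treated as independent; this finding rests on the single low number of compound 2, and it does not show why the effect differs or whether other aryl groups would behave the same way.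

The compounds shown leave open whether an unsubstituted phenyl on the amide carbonyl would fall on the ester as 4-chlorophenyl does, and whether a methyl ester or a primary amide would behave like the ethyl ester or like the acid. Also open, as far as these compounds go, is whether compound 1, compound 3 and compound 4 would separate at a lower concentration, since a reading at one concentration is not a potency.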